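The source may report more compounds than this note shows. Statements on the series, on what has been measured and on what is new or still open speak of the compounds shown alone.

Measured so far in a functional assay on the whole organism (Ear) for inhibition, with Mus musculus as the target, with a stated time of 30 min, at a dose of 100 mg/kg by the intraperitoneal route; on this read-out lower numbers stand for less inhibition and higher numbers for more inhibition at the one dose given (going by the name of the read-out):

- compound 1 `N=C(N)N/N=C/c1ccc(/C=C/C(=O)c2ccc(Cl)cc2)cc1` gives 56.4%
- compound 2 `COc1ccc(C(=O)/C=C/c2ccc(/C=N/NC(=N)N)cc2)cc1` gives 57.2%
- compound 3 `N=C(N)N/N=C/c1ccc(/C=C/C(=O)c2ccc(F)cc2)cc1` gives 90.7%

Compound 3 stands highest of the three; the gap to compound 2 and to compound 1 is beyond the scatter in both cases, so it gives the highest number of the measured set. The two measured steps ending at compound 3, a number 34.3 percentage points higher from compound 1 to compound 3 (beyond the scatter) and a number 33.5 percentage points higher from compound 2 to compound 3 (beyond the scatter), are large, whereas a number 0.8 percentage points higher from compound 1 to compound 2 (within the scatter) lies within the scatter.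

Compound 4 `N=C(N)N/N=C/c1ccc(/C=C/C(=O)c2ccccc2F)cc1` differs from compound 3 by 2-fluorophenyl in place of 4-fluorophenyl on a carbonyl carbon. For the measured compounds named here, none of the measured steps changes where the fluorine sits; all three exchange one substituent for another at the same place on the aromatic ring. They therefore bear on the change only indirectly: they show that this part of the molecule can move the read-out in this assay by large amounts, but give no direction for the present change. The expectation is a step of uncertain direction, most likely some loss from the highest number, with a wide range.

Compound 4 is therefore estimated to give 70%, in the range 45% to 95%. This estimate corresponds to an expected step of a number 20.7 percentage points lower from compound 3 to compound 4 (beyond the scatter).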

Compound 4, a percentage reported as inhibition, in the whole organism at one dose (the size of the read-out at that dose, not a potency): 91.7%
For compound 4 the middle estimate is 21.7 percentage points below the measured one; low and high end bracket the measured number.
By their numbers in this assay, from the lowest: compounds 1 and 2 (each within the scatter of the next); then compounds 3 and 4 (each within the scatter of the next).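

In this assay, for the compounds shown here, 2-fluorophenyl in place of 4-fluorophenyl on the carbonyl carbon gives a number 1 percentage points higher from compound 3 to compound 4 (within the scatter), so the two fluorine placements are not told apart by this read-out; the earlier steps all exchanged one substituent for another at a single place and could not show this. The other two steps, a number 34.5 percentage points higher from compound 2 to compound 4 (beyond the scatter) and a number 35.3 percentage points higher from compound 1 to compound 4 (beyond the scatter), show that the high number is not confined to the 4-fluorophenyl compound, with both fluorophenyl compounds standing clear of the 4-methoxyphenyl and 4-chlorophenyl compounds. No evidence is available here that bears on this result.

Going by these compounds, whether chloro or methoxy would behave the same way if moved as fluoro was remains open, as does the outcome of an amine or a carboxylic acid in place of the fluorine. On these data alone, with a single dose behind each number, any difference in potency between compound 3 and compound 4 also remains open.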